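The compounds below may be only part of what the source reports. "The series", "measured", "known", "first", "only" and "open" are said of these compounds alone.

Working notes on the series.

Going by the values given here, in a functional assay on AGS cells (Homo sapiens) for antiproliferative activity, read by CCK-8 assay, with a stated time of 72 h (on this read-out higher numbers stand for weaker inhibition and lower numbers for stronger inhibition), compound 1 `O=C(Nc1ccc(-c2cnc3cc(N4CCN(C5CC5)CC4)ccn23)cc1)c1ccc([N+](=O)[O-])o1` gives 1920 nM, the highest of the three numbers measured so far; its nearest neighbour is compound 2 `CC1(O)CCN(c2ccn3c(-c4ccc(NC(=O)c5ccc([N+](=O)[O-])o5)cc4)cnc3c2)CC1`, which in this assay gives 1530 nM, and furthest from it is compound 3 `O=C(Nc1ccc(-c2cnc3cc(Br)ccn23)cc1)c1ccc([N+](=O)[O-])o1`, which in this assay gives 560 nM. The two steps away from compound 1 are a 1.3-fold lower number from compound 1 to compound 2 (0.10 log units; within the scatter) and a 3.4-fold lower number from compound 1 to compound 3 (0.54 log units; beyond the scatter); between the other two compounds the step is a 2.7-fold lower number from compound 2 to compound 3 (0.44 log units; beyond the scatter).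

Compound 4 `COc1ccn2c(-c3ccc(NC(=O)c4ccc([N+](=O)[O-])o4)cc3)cnc2c1` has not yet been measured. Its difference from compound 1 is methoxy in place of 4-cyclopropylpiperazin-1-yl on an aromatic carbon. Among the compounds with values here, two measured steps bear on this one. Exchanging the 4-cyclopropylpiperazin-1-yl group for another ring-bearing group, in a 1.3-fold lower number from compound 1 to compound 2 (0.10 log units; within the scatter), stayed within the scatter, whereas exchanging it for bromo, a group with no ring, in a 3.4-fold lower number from compound 1 to compound 3 (0.54 log units; beyond the scatter), gave a modest lowering. Methoxy, also a group with no ring, is expected to behave more like the bromo case, so a modest lowering is expected, a 2.3-fold lower number from compound 1 to compound 4 (0.35 log units; beyond the scatter). Compound 4 is therefore estimated at 850 nM in this assay, with a range of 350 nM to 2000 nM.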

Compound 4, half-maximal inhibitory concentration: 720 nM
Estimate against measurement, compound 4: 1.2-fold (0.07 log units) above, within the range that was stated.
By their numbers in this assay, from the lowest: compounds 3 and 4 (each within the scatter of the next); then compounds 2 and 1 (each within the scatter of the next).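

In this assay, a 2.7-fold lower number from compound 1 to compound 4 (0.43 log units; beyond the scatter) shows that the lowering seen with bromo is not unique to that group, as a 1.3-fold higher number from compound 3 to compound 4 (0.11 log units; within the scatter) stays within the scatter while a 2.1-fold lower number from compound 2 to compound 4 (0.33 log units; beyond the scatter) lies beyond it. Going by these compounds alone, at this position, opposite the ring nitrogen, the four compounds now form two groups: the ringless bromo and methoxy compounds 3 and 4 at the lower numbers, and the ring-bearing compounds 1 and 2 at the higher numbers, with no compound going against this split. No measured evidence accompanies these results that could account for the split.

As far as these compounds go, how an open-chain amine such as dimethylamino or a longer ether chain such as propoxy would fall at this position remains open. Also open, from the compounds shown here alone, is whether the higher numbers go with the ring itself or with the overall size of the group.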